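This account rests on a few compounds, and the source may have more. Where it says the series, first, only, none or still open, it means among the compounds named here.

Measured in a functional assay on MES-SA/Dx5 cells (Homo sapiens) for inhibition, read by fluorescence, with a stated time of 72 h; on this read-out lower numbers stand for stronger inhibition and higher numbers for weaker inhibition:
- compound 1 `Oc1ccccc1/C=N/NC(=S)Nc1ccccc1`: 4790 nM; 6450 nM (2 entries)
- compound 2 `COc1ccc(NC(=S)N/N=C/c2ccccc2O)cc1`: 1850 nM

Among the measured compounds shown here, compound 2, at 1850 nM, holds the only single number, the other entry being (the several entries of compound 1 in this assay, 4790 nM; 6450 nM (2 entries)). Compound 3 `Cc1ccc(NC(=S)N/N=C/c2ccccc2O)cc1` is still unmeasured. It carries methyl in place of methoxy on an aromatic carbon, para to a large group: methyl in place of methoxy on an aromatic carbon. For the measured compounds named here, no measured step covers this change, so the expectation in this assay rests on compound 2 at 1850 nM, with no direction and no shift beyond the scatter. The expected change is a 1.1-fold higher number from compound 2 to compound 3 (0.03 log units; within the scatter). Compound 3 is estimated at 2000 nM, with an expected range of 700 nM to 5500 nM.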

Compound 3, half-maximal inhibitory concentration: 1870 nM
Beside the measured number, compound 3's estimate is 1.1-fold (0.03 log units) above it; low and high end bracket the measured number.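

Among the compounds shown here, the first readable step at this position, an aromatic carbon para to a large group, comes from methyl in place of methoxy in this assay: a 1.0-fold higher number from compound 2 to compound 3 (0.00 log units; within the scatter). For this pair, giving up the hydrogen-bond acceptor of methoxy goes with no shift beyond the scatter. Repeated entries, available for only one compound, show how closely values in this assay can agree: the several entries of compound 1 in this assay, 4790 nM; 6450 nM (2 entries)

The compounds shown leave open how an amine, a carboxylic acid or a longer chain would read at this position. Two groups there establish no trend.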